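Methyl Substitution Carried from a Lactone to an Open-Chain Ester

This account rests on a few compounds, and the source may have more. Where it says the series, first, only, none or still open, it means among the compounds named here.

Compound 1 `O=C1C=CC[C@H](c2cccc3ccccc23)O1` and compound 2 `Cc1ccc2ccccc2c1[C@H]1CC=CC(=O)O1` share a core, and compound 2 differs only by methyl in place of hydrogen on an aromatic carbon. In a functional assay on PC-3 cells (Homo sapiens) for cytotoxicity, read by MTT assay, with a stated time of 48 h (on this read-out higher numbers stand for weaker inhibition and lower numbers for stronger inhibition), compound 1 gives 800 nM, while compound 2 gives 130 nM, so that a 6.2-fold lower number from compound 1 to compound 2 (0.79 log units; beyond the scatter). Compound 3 `C=CC[C@@H](OC(=O)C=C)c1cccc2ccccc12` has a different core; how its core differs from that of compound 1 is not broken down here. In this assay compound 3 gives 22900 nM, the highest of the three numbers. Compound 4 `C=CC[C@@H](OC(=O)C=C)c1c(C)ccc2ccccc12` is not yet measured and differs from compound 3 by methyl in place of hydrogen on an aromatic carbon; as the methyl enters ortho to a group of 9 heavy atoms rather than 7, this is the same kind of change as before, not the same. Because a 6.2-fold lower number from compound 1 to compound 2 (0.79 log units; beyond the scatter) was modest, the expected step is a 4.2-fold lower number from compound 3 to compound 4 (0.62 log units; beyond the scatter). Compound 4 is therefore estimated at 5500 nM, between 1800 nM and 17000 nM.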

Compound 4, half-maximal inhibitory concentration: 8800 nM
Compound 4: the middle estimate sits 1.6-fold (0.20 log units) below what was measured; the range from low to high includes it.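

On the core of compound 3, methyl in place of hydrogen on an aromatic carbon again lowered the number in this assay, with a 2.6-fold lower number from compound 3 to compound 4 (0.42 log units; beyond the scatter). The two steps run in the same direction and cannot be told apart in size: the same change on two cores in this assay, a 6.2-fold lower number (0.79 log units; beyond the scatter) from compound 1 to compound 2 and a 2.6-fold lower number (0.42 log units; beyond the scatter) from compound 3 to compound 4, 2.4-fold (0.37 log units) apart, within the scatter of two such steps. For the compounds shown here, this shows that the change carried over from the core of compound 1 to the core of compound 3, but with only two cores it does not show why the number falls or whether the same would hold on any other core.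

The compounds shown leave open whether an ethyl group, a methoxy group, a chlorine atom or an amine on that same aromatic carbon would lower the number as methyl does. They also leave open whether methyl would have the same effect on another carbon of that ring.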